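The compounds below may be only part of what the source reports. "The series", "measured", "known", "first", "only" and "open" are said of these compounds alone.

Working notes on the series. The read-out is an ADME assay on MT4 cells (Homo sapiens) for activation, read by MTT assay; on this read-out lower numbers stand for higher toxicity in this test and higher numbers for lower toxicity in this test.

Compound 1 `O=c1cc(Cc2c(F)cccc2Cl)nc(SC2CCCC2)[nH]1` is measured only as a limit of this assay, > 74000 nM (the limit of > 74000 nM in this assay, at which 1 of the 3 values shown sits). Compound 2 `CC(c1cc(=O)[nH]c(SC2CCCC2)n1)c1c(F)cccc1Cl` is likewise measured only as a limit, > 71000 nM (the limit of > 71000 nM in this assay, at which 1 of the 3 values shown sits). Compound 3 `CCCSc1nc(C(CC)c2c(F)cccc2Cl)c(C)c(=O)[nH]1` too is measured only as a limit, > 3000 nM (the limit of > 3000 nM in this assay, at which 1 of the 3 values shown sits). The difference between the cores of compound 1 and compound 3 is not broken down here.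

Compound 4 `CCC(C)Sc1nc(C(CC)c2c(F)cccc2Cl)c(C)c(=O)[nH]1` is not yet measured. It differs from compound 3 by methyl in place of hydrogen on a saturated chain carbon bound to a saturated chain carbon and a sulfur. The same kind of change, (methyl in place of hydrogen on a saturated chain carbon bound to two aromatic carbons), sits on a saturated chain carbon bound to two aromatic carbons, whereas in compound 4 it sits on a saturated chain carbon bound to a saturated chain carbon and a sulfur; the step it made, a step that the two limits leave unreadable from compound 1 to compound 2, is not readable in size between two limits.

With three limits and no readable step, the step from compound 3 to compound 4 is expected to be about a step that the limit leaves unreadable from compound 3 to compound 4, and a further limit is likely. Compound 4 is estimated at 40000 nM, within 5000 nM to 150000 nM.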

Compound 4, half-maximal cytotoxic concentration: > 3000 nM
Compound 4: a limit, no number; the forecaster's own chance of this, stated with the estimate: 80%; the middle value is on the limit's open side.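

Compound 3 and compound 4 both stand only as limits in this assay, and no step can be read between them. The compounds shown leave open whether methyl in place of hydrogen changes this read-out at all, and at what concentration any of them becomes toxic in this test.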